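A few compounds are considered here, and "the series" means these few. Any claim that something is new, unique, unknown or untested is made for them only; others in the source may bear on it.

Measured compounds:
- compound 1, `COc1ccccc1C#Cc1nc2c(s1)C(=O)NCC2`: in an assay on HEK293 cells for negative allosteric modulation of metabotropic glutamate receptor 5 (Homo sapiens), read by FLIPR, with a stated time of 1 h (a lower number here means a stronger inhibitor, a higher number a weaker inhibitor), compound 1 gives > 10000 nM, which is a limit of the assay rather than a number.
- compound 2, `CC1CC1C(=O)N1CCc2nc(C#Cc3ccccc3)sc2C1`: in this assay compound 2 gives > 10000 nM, again a limit of the assay and not a number.

Compound 2 therefore stands at the edge of what this assay can report. Among the measured compounds shown here, it shares that position with the only other value shown, as the limit of > 10000 nM in this assay, at which 2 of the 2 values shown sit, makes plain, so no measured step between two numbered values exists here, and nothing shows how far below the limit either compound might actually lie.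

Compound 3, `O=C(CC1CCOCC1)N1CCc2nc(C#Cc3ccccc3)sc2C1`, has not yet been tested. It differs from compound 2 in one place: (oxan-4-yl)methyl in place of 2-methylcyclopropyl on a carbonyl carbon. For the measured compounds named here, with both known values sitting at the same limit, there is no measured step to lean on, and the expectation is a step from compound 2 to compound 3 of about none beyond the scatter, a number no higher from compound 2 to compound 3 (the limit leaves the size open). Compound 3 is accordingly estimated at 10000 nM in this assay, within a range from 3000 nM to 30000 nM, and a further limit rather than a number is the more likely outcome.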

Compound 3, half-maximal inhibitory concentration: > 10000 nM
Compound 3: no number, only a limit (the forecaster's own chance of this, stated with the estimate: 70%); the middle value lies on the limit itself.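

In this assay compound 3 gives > 10000 nM, which is a limit of the assay and not a number. Compound 2 also stands at a limit, so no step can be read from compound 2 to compound 3. The compounds shown leave open how strongly each one inhibits, since all of them share one result: the limit of > 10000 nM in this assay, at which 3 of the 3 values shown sit.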